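The Same Group Swap on a Second Core

The source may hold more compounds than are shown below. What is called first, only, known or untested is meant among the compounds shown, and "the series" means these compounds.

Compound 1 `CCCCCCCCc1ccc(OCC(=O)Cn2nnc(-c3ccccc3Cl)n2)cc1` and compound 2 `CCCCCCCCc1ccc(OCC(=O)Cn2nnc(-c3ccc(S(=O)(=O)N(C)C)cc3)n2)cc1` share a core and differ in one group. Compound 3 `CCCCCCCCc1ccc(OCC(=O)Cn2nnnc2-c2ccccc2Cl)cc1` has the same atoms as compound 1 joined differently, and compound 4 `CCCCCCCCc1ccc(OCC(=O)Cn2nnnc2-c2ccc(S(=O)(=O)N(C)C)cc2)cc1` relates to compound 3 as compound 2 relates to compound 1. How the two cores differ is not broken down here.

In an ADME assay on S9 fraction from liver (Rattus norvegicus) for metabolic stability, read by LC-MS, using NADPH, with a stated time of 30 min (a higher number here means that more of the compound is left, a lower number that less of the compound is left), compound 1 gives 28% and compound 2 gives 65%. The change between them is 4-(dimethylsulfamoyl)phenyl in place of 2-chlorophenyl on an aromatic carbon and it made a step of a number 37 percentage points higher from compound 1 to compound 2 (beyond the scatter). Compound 3 gives 42% in this assay, a value standing apart from both.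

The change from compound 3 to compound 4 is 4-(dimethylsulfamoyl)phenyl in place of 2-chlorophenyl on an aromatic carbon. The place is described differently: in compound 3 the changed carbon is next to the ring atom that bears a large group, whereas in compound 1 it is two ring bonds from that atom, so this is the same kind of change, not the same one. For compound 4 a step of a number 30 percentage points higher from compound 3 to compound 4 (beyond the scatter) is expected, somewhat smaller than the earlier one because compound 3 already starts from 42% and the read-out cannot exceed full recovery. Compound 4 is therefore estimated at 72%, with a likely range from 55% to 88%.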

Compound 4, percent of the compound remaining: 40%
The estimate for compound 4 lay 32 percentage points above the measured number, outside the stated range (below it).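

In this assay, the exchange of 2-chlorophenyl for 4-(dimethylsulfamoyl)phenyl did not behave alike on the two cores, and the gap between the two steps is larger than chance scatter would explain: the same change on two cores in this assay, a number 37 percentage points higher (beyond the scatter) from compound 1 to compound 2 and a number 2 percentage points lower (within the scatter) from compound 3 to compound 4, 39 percentage points apart, beyond the scatter of two such steps On the core of compound 3, the exchange gave a number 2 percentage points lower from compound 3 to compound 4 (within the scatter), so compound 3 and compound 4 cannot be told apart here, and the large rise seen on the core of compound 1 cannot be assumed to carry over to the other core. This rests on one pair of compounds per core in a single assay, so it shows that the outcome of this exchange depends on the core, but not what in the way the atoms are joined causes that dependence.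

As far as these compounds go, it remains open whether a nitrile or a carboxylic acid in place of the dimethylsulfamoyl group would also give different results on the two cores. From the compounds shown here alone, it is equally open whether a hexyl chain in place of the octyl chain would change the picture on either core.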